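The compounds below may be only part of what the source reports. "The series", "measured", "known", "first", "only" and "open" are said of these compounds alone.

Measured so far:
- Compound 1, `CN(C)CCNc1ccnc2cc(OCc3ccc(F)cc3)ccc12`, gives 790 nM in a functional assay on HepG2 cells (Homo sapiens) for cytotoxicity, read by MTT assay, with a stated time of 48 h; a lower number here means a stronger inhibitor, a higher number a weaker inhibitor.
- Compound 2, `CC(C)COc1ccc2c(Cl)ccnc2c1`, gives 2250 nM in this assay.
- Compound 3, `CCCCOc1ccc2c(Cl)ccnc2c1`, gives 2640 nM in this assay.

Compound 3 has the highest number of the three in this assay. Its nearest neighbour is compound 2, and the step of a 1.2-fold higher number from compound 2 to compound 3 (0.07 log units; within the scatter) lies within the scatter, so the two cannot be told apart. Compound 1 stands further away with a lower number, and that gap is beyond the scatter.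

The next compound, compound 4, `CCCCCCCCOc1ccc2c(Cl)ccnc2c1`, carries a change on the chain that hangs from the oxygen: butyl in place of hydrogen on a saturated chain carbon, four bonds along the chain from an oxygen on an aromatic ring. Among the measured pairs only the step from compound 2 to compound 3 touches this chain, and it was within the scatter. Among the measured compounds shown here, a much longer chain than anything measured here has no direct precedent, so the expectation rests on that one small step. The estimated step of a 1.1-fold lower number from compound 3 to compound 4 (0.02 log units; within the scatter) is therefore expected to stay within the scatter, with a wide range to allow for the unprecedented chain length. For compound 4 the estimate in this assay is 2500 nM, with a range from 800 nM to 8000 nM.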

Compound 4, half-maximal inhibitory concentration: 2640 nM
Estimate against measurement, compound 4: 1.1-fold (0.02 log units) below; the measured number falls inside the stated range.
By their numbers in this assay, from the lowest: compound 1; then compounds 2, 3 and 4 (each within the scatter of the next).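

In this assay butyl in place of hydrogen on a saturated chain carbon, four bonds along the chain from an oxygen on an aromatic ring, gives no change at the digits printed from compound 3 to compound 4 (within the scatter) and so adds real length to the chain without a readable effect on the number. The earlier step at this chain only exchanged isopropyl for propyl, whereas this one shows that, for compounds 2, 3 and 4, neither that exchange nor this added butyl separates the compounds in this cell test. No measurement here explains why the number stays put.

On these data alone, whether an amine or a carboxylic acid at the end of this chain would move the number remains open, as does the outcome for a much shorter group such as methyl. Also open, as far as these compounds go, is what replacing the chlorine on the shared core would do while this chain stays in place.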